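The source may report more compounds than this note shows. Statements on the series, on what has been measured and on what is new or still open speak of the compounds shown alone.

Compound 1 `CN(c1cccc2c1CN(c1nc(Nc3ccc(Cl)c(C(F)(F)F)c3)ncc1C(F)(F)F)C2)S(C)(=O)=O` is the starting point. In a functional assay on A549 cells (Homo sapiens) for antiproliferative activity, read by spectrophotometry, with a stated time of 2 days (a higher number here means a weaker inhibitor of growth, a lower number a stronger inhibitor of growth), compound 1 gives 15200 nM, the higher of the two numbers measured, while compound 2 `CC(=O)N1CCN(c2ccc(Nc3ncc(C(F)(F)F)c(N4Cc5cccc(N(C)S(C)(=O)=O)c5C4)n3)cc2)CC1` gives 1300 nM, a gap beyond the scatter. Compound 3 `Cc1cc(C)cc(Nc2ncc(C(F)(F)F)c(N3Cc4cccc(N(C)S(C)(=O)=O)c4C3)n2)c1` reaches only a limit of this assay, > 30000 nM. Going by the values given here, the one comparable step, an at least 1.9-fold higher number from compound 1 to compound 3 (0.29 log units; that floor lies within the scatter), changes the same aromatic amine substituent as the step now followed. Compound 4 `Cc1ccc(Nc2ncc(C(F)(F)F)c(N3Cc4cccc(N(C)S(C)(=O)=O)c4C3)n2)c(C)c1` carries 2,4-dimethylphenyl in place of 4-chloro-3-(trifluoromethyl)phenyl on a nitrogen on an aromatic ring. Given that compound 3 sits at the limit of > 30000 nM in this assay, at which 1 of the 3 values shown sits, compound 4 is expected to move the same way, with a step of a 2.0-fold higher number from compound 1 to compound 4 (0.30 log units; within the scatter), probably ending at the limit as well. The estimate for compound 4 is 30000 nM, within 12000 nM to 80000 nM.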

Compound 4, concentration for 50% growth inhibition: 20700 nM
Compound 4: the middle estimate sits 1.4-fold (0.16 log units) above what was measured, and the stated range covers the measured number.
By their numbers in this assay, from the lowest: compound 2; then compounds 1 and 4 (each within the scatter of the next). At a limit, above all of these: compound 3.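

Swapping 4-chloro-3-(trifluoromethyl)phenyl for 2,4-dimethylphenyl on this nitrogen leaves no change that can be told from scatter, the step being a 1.4-fold higher number from compound 1 to compound 4 (0.13 log units; within the scatter). The 2,4-dimethylphenyl and 3,5-dimethylphenyl groups cannot be ordered either, with an at least 1.4-fold lower number from compound 3 to compound 4 (0.16 log units; that floor lies within the scatter). Compound 3 gives a limit and not a number: the limit of > 30000 nM in this assay, at which 1 of the 4 values shown sits.

Going by these compounds, whether a phenyl ring carrying a morpholine or a carboxylic acid on this nitrogen would move the number beyond the scatter stays open. So does the effect of a pyridine in place of the phenyl ring.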